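Alkoxy chain replaced by piperidine on the core

The source may hold more compounds than are shown below. What is called first, only, known or untested is meant among the compounds shown, and "the series" means these compounds.

compound 1, `CCCOc1c(C(=O)N(C)Cc2cc(C(F)(F)F)cc(C(F)(F)F)c2)c(=O)n(C)c2ccccc12`: in an ADME assay for inhibition of phosphatidylcholine:ceramide cholinephosphotransferase 1 (Homo sapiens), read by mass spectrometry, with stated times of 60 min and 30 min (a higher number here means a weaker inhibitor, a lower number a stronger inhibitor), compound 1 gives > 100000 nM, a limit of the assay.
compound 2, `CC(C)CCOc1c(C(=O)N(C)Cc2cc(C(F)(F)F)cc(C(F)(F)F)c2)c(=O)n(C)c2ccccc12`: in this assay compound 2 gives > 100000 nM, also a limit.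
compound 3, `CN(Cc1cc(C(F)(F)F)cc(C(F)(F)F)c1)C(=O)c1c(OCCCC2CCCCC2)c2ccccc2n(C)c1=O`: in this assay compound 3 gives 14000 nM.

Within the data shown here, compound 3 holds the only number in the set; the other two values sit at the limit of > 100000 nM in this assay, at which 2 of the 3 values shown sit. Both measured steps that reach a number run downward: an at least 7.1-fold lower number from compound 1 to compound 3 (0.85 log units; beyond the scatter) and an at least 7.1-fold lower number from compound 2 to compound 3 (0.85 log units; beyond the scatter), each beyond the scatter, with the cyclohexyl-bearing chain present in compound 3 only. The step that the two limits leave unreadable from compound 1 to compound 2, between two limits, gives no size.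

Compound 4, `CN(Cc1cc(C(F)(F)F)cc(C(F)(F)F)c1)C(=O)c1c(N2CCCCC2)c2ccccc2n(C)c1=O`, differs from compound 3 by piperidin-1-yl in place of 3-cyclohexylpropoxy on an aromatic carbon. The 3-cyclohexylpropoxy group, whose entry accompanied the lower number in both readable steps, leaves, and a six-membered ring with one hetero atom enters directly on the aromatic carbon. Nothing measured carries that ring, so the step rests on the loss of the chain alone. In this assay compound 4 is therefore expected to return toward the limit, a step of a 7.1-fold higher number from compound 3 to compound 4 (0.85 log units; beyond the scatter). The estimate for compound 4 is 100000 nM, within 30000 nM to 300000 nM, with a fair chance that only a limit is reported.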

Compound 4, half-maximal inhibitory concentration: > 100000 nM
Compound 4 was reported as a limit (the forecaster's own chance of this, stated with the estimate: 60%); the middle value sits exactly at the limit.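

In this assay, setting piperidin-1-yl on this aromatic carbon in place of 3-cyclohexylpropoxy gives an at least 7.1-fold higher number from compound 3 to compound 4 (0.85 log units; beyond the scatter). A six-membered non-aromatic ring placed directly on the aromatic carbon therefore does not keep the measurable inhibition, so having a ring in the group is not enough at this position. Among these compounds, the steps that join compound 4 to compound 1 and compound 2 run between limits and cannot be read, and the set still holds only one number: the limit of > 100000 nM in this assay, at which 3 of the 4 values shown sit.

Going by these compounds, it remains open whether a piperidine carrying a longer chain or a cyclohexylpropylamino group, with nitrogen in place of the ether oxygen, would restore a number. On these data alone, how far compound 1, compound 2 and compound 4 lie beyond the limit also stays unknown.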